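This account rests on a few compounds, and the source may have more. Where it says the series, first, only, none or still open, it means among the compounds named here.

In a physicochemical assay for lipophilicity (on this read-out higher numbers stand for higher lipophilicity and lower numbers for lower lipophilicity), compound 1 (`C/C=C/C=C/C(=O)OCCCC`) gives 2.71, the lower of the two numbers at hand, while compound 2 (`C/C=C/C=C/C(=O)OCCCCCCC`) gives 3.9. Compound 3 (`C=CCOC(=O)/C=C/C=C/C`) has not yet been measured and differs from compound 1 by one change: vinyl in place of propyl on a saturated chain carbon bound to an oxygen next to a carbonyl group. Read one bond further out, butyl becomes allyl. Going by the values given here, only one measured step bears on this, and it is large: a number 1.19 log units higher from compound 1 to compound 2 (beyond the scatter), with a longer chain in the higher compound. Among the compounds with values here, the new change runs the other way and is smaller, and no measured step covers its double bond. A moderate downward step in this assay, beyond the scatter, is therefore expected. The expected change is a number 0.56 log units lower from compound 1 to compound 3 (beyond the scatter). Compound 3 is estimated at 2.15, within an expected range from 1.85 to 2.45.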

Compound 3, partition coefficient: 2.24
The estimate for compound 3 lay 0.09 log units below the measured number, within the range that was stated.
By their numbers in this assay, from the lowest: compound 3; then compound 1; then compound 2.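

Going by these compounds alone, until this result, the only measured change at this chain had lengthened it, and the number had risen. In this assay, vinyl in place of propyl on a saturated chain carbon bound to an oxygen next to a carbonyl group gives a step in the other direction, a number 0.47 log units lower from compound 1 to compound 3 (beyond the scatter), so this position also responds to a smaller group that carries a double bond, and the step is clearly smaller than the one seen on lengthening the chain, a number 1.19 log units higher from compound 1 to compound 2 (beyond the scatter). Nothing at hand accounts for the size or direction of this new step.

The compounds shown do not separate the double bond from the shorter chain, since this single step changes both at once. An ethyl group on the same carbon would bear on that question, and an amine or a carboxylic acid at the end of the chain remains outside what these compounds cover.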